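Cytotoxicity Estimate for a Chlorophenyl Analogue

A few compounds are considered here, and "the series" means these few. Any claim that something is new, unique, unknown or untested is made for them only; others in the source may bear on it.

Measured compounds:
compound 1, `Cc1ccc(-c2ccc(C(=O)N[C@H](c3nc(C)c(CCO)s3)[C@@H]3CCCCN3)[nH]2)cc1F`: 29700 nM
compound 2, `Cc1ccc(-c2ccc(C(=O)N[C@@H](c3nc(C)c(CCO)s3)[C@@H]3CCCCN3)[nH]2)cc1F`: 21200 nM

In a toxicity assay on MT2 cells (Homo sapiens) for cytotoxicity, read by XTT assay, with a stated time of 4 days (a higher number here means that more compound is tolerated, a lower number that less compound is tolerated), compound 1 gives 29700 nM and compound 2 gives 21200 nM. Compound 2 holds the lower of the two numbers, but the step of a 1.4-fold lower number from compound 1 to compound 2 (0.15 log units; within the scatter) lies within the scatter, and the two compounds differ only in configuration as drawn, as shown by the fact that compounds 1 and 2 differ only in the configuration as drawn.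

Compound 3, `Cc1nc([C@H](NC(=O)c2ccc(-c3ccc(Cl)cc3)[nH]2)[C@@H]2CCCCN2)sc1CCO`, has not yet been measured. Its change from compound 2 is 4-chlorophenyl in place of 3-fluoro-4-methylphenyl on an aromatic carbon. Within the data shown here, no measured step speaks to this exchange: the single step of a 1.4-fold lower number from compound 1 to compound 2 (0.15 log units; within the scatter) concerns configuration alone and gives no guidance on replacing one aromatic ring by another. With nothing to argue for a shift, the expected step into compound 3 is a 1.0-fold higher number from compound 2 to compound 3 (0.02 log units; within the scatter), no larger than the scatter. For compound 3 the estimate in this assay is 22000 nM, with a range from 9000 nM to 50000 nM.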

Compound 3, half-maximal cytotoxic concentration: 21000 nM
Estimate against measurement, compound 3: 1.0-fold (0.02 log units) above; the range from low to high includes it.
By their numbers in this assay, from the lowest: compounds 3, 2 and 1 (each within the scatter of the next).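

In this assay, the exchange of 3-fluoro-4-methylphenyl for 4-chlorophenyl gives a 1.0-fold lower number from compound 2 to compound 3 (0.00 log units; within the scatter), so this pair cannot be told apart in this assay. Among these compounds, compounds 1 and 2 spoke only to configuration, whereas this pair gives the first reading at the aromatic carbon next to the ring nitrogen, and there two differently substituted phenyl groups with the same six-membered aromatic carbon ring give numbers within the scatter of each other. Nothing available here accounts for this result.

The compounds shown leave open whether the same holds for a phenyl ring bearing an amine or a carboxylic acid, or for a saturated cyclohexyl ring at this carbon. They also leave open whether a 4-chlorophenyl group behaves the same way in the configuration of compound 1.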